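Shared core series: variation at the aromatic nitrogen substituent

The source may hold more compounds than are shown below. What is called first, only, known or untested is meant among the compounds shown, and "the series" means these compounds.

Measured so far:
compound 1 `COc1ccc(Cn2c(=O)n(C3OC(CO)[C@@H](O)[C@H]3O)c3nc(N)nc(O)c32)cc1`: 14%
compound 2 `CCOC(=O)Cn1c(=O)n(C2OC(CO)[C@@H](O)[C@H]2O)c2nc(N)nc(O)c21`: 58%

In a functional assay on the whole organism with Mus musculus as the target (on this read-out lower numbers stand for smaller maximal responses and higher numbers for larger maximal responses), compound 2 stands highest of the two numbers; the nearest is compound 1, reached by a number 44 percentage points higher from compound 1 to compound 2 (beyond the scatter). Compound 3 `CCCCCCCCCCn1c(=O)n(C2OC(CO)[C@@H](O)[C@H]2O)c2nc(N)nc(O)c21` is not yet measured. It differs from compound 2 by nonyl in place of ethoxycarbonyl on a saturated chain carbon bound to an aromatic nitrogen. Among the measured compounds shown here, the only step that bears on this place is the one from compound 1 to compound 2, and it was large, so a change at this place can move the read-out far. The direction for a nonyl is not settled by the shown steps, so a step of moderate size downward is expected, a number 18 percentage points lower from compound 2 to compound 3 (beyond the scatter). Compound 3 is estimated at 40%, range 10% to 75%.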

Compound 3, largest response reached (reported as maximal response), in percent of the reference or control that the assay uses: 0%
Compound 3: the middle estimate sits 40 percentage points above what was measured; measured number below the stated range.
By their numbers in this assay, from the lowest: compound 3; then compound 1; then compound 2.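

In this assay, this place on a saturated chain carbon bound to an aromatic nitrogen can take the read-out down as well as up: nonyl in place of ethoxycarbonyl gives a number 58 percentage points lower from compound 2 to compound 3 (beyond the scatter). Nonyl in place of 4-methoxyphenyl also gives a lower number, a number 14 percentage points lower from compound 1 to compound 3 (beyond the scatter), so nonyl ranks lowest of the three groups. No available evidence accounts for this order. Open, on these data alone, is whether a shorter chain such as ethyl or a longer chain such as dodecyl would also give a low response. Also open, as far as these compounds go, is how a carboxylic acid or an amine at this place would compare with ethoxycarbonyl.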